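This account rests on a few compounds, and the source may have more. Where it says the series, first, only, none or still open, it means among the compounds named here.

Measured so far:
- compound 1 `N=C(N)c1ccc(CNC(=O)N2CCN(C(=O)O[C@H]3CCC[C@@H](OC(=O)N4CCN(C(=O)NCCC5CCNCC5)CC4)CCC3)CC2)cc1`: 47200 nM
- compound 2 `N=C(N)c1ccc(C(=O)NCC2CCN(C(=O)O[C@H]3CCC[C@@H](OC(=O)N4CCN(C(=O)NCCC5CCNCC5)CC4)CCC3)CC2)cc1`: 38800 nM

In an assay on cells for inhibition of Trypsin (Homo sapiens) (on this read-out lower numbers stand for stronger inhibition and higher numbers for weaker inhibition), compound 1 gives 47200 nM, the highest of the two numbers shown, and compound 2 gives 38800 nM, a difference that lies within the scatter, so the two compounds cannot be told apart on this assay. Both carry the same core, and both are weak inhibitors.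

Compound 3 `N=C(N)c1ccc(CNC(=O)N2CCN(C(=O)O[C@H]3CCC[C@@H](OC(=O)N4CCN(C(=O)CCCC5CCNCC5)CC4)CCC3)CC2)cc1` is not yet measured. It differs from compound 1 in one place: 3-(piperidin-4-yl)propyl in place of (2-(piperidin-4-yl)ethyl)amino on a carbonyl carbon. The change removes one hydrogen-bond donor on the carbonyl carbon at the far end of the molecule, while the amidine-bearing end stays the same.

Because compound 1 gives 47200 nM and compound 2 gives 38800 nM with a quite different link at the other end, the outer tail seems to matter little here. The step of a 1.1-fold higher number from compound 1 to compound 3 (0.03 log units; within the scatter) is therefore expected to stay within the scatter, in no clear direction. Compound 3 is estimated at 50000 nM, with a range from 15000 nM to 160000 nM.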

Compound 3, inhibition constant: 52100 nM
Compound 3: middle estimate off by 1.0-fold (0.02 log units), on the low side; the range from low to high includes it.
By their numbers in this assay, from the lowest: compounds 2, 1 and 3 (each within the scatter of the next).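

The change gives a 1.1-fold higher number from compound 1 to compound 3 (0.04 log units; within the scatter) in this assay, so compound 1 and compound 3 cannot be told apart on this read-out. Going by these compounds alone, this is the first pair here that differs in one place, and it shows that, on this carbonyl carbon, 3-(piperidin-4-yl)propyl can stand in place of (2-(piperidin-4-yl)ethyl)amino with no detectable difference, even though the amino nitrogen and its hydrogen are gone. No measurement is available that could explain this result.

Going by these compounds, it remains open whether a shorter chain, a longer chain or a carboxylic acid at the end of the tail would give a clearly different number. On these data alone, it is also open whether the same swap would behave alike on the core of compound 2.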